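Thiazole for pyridine on the ring-amine methylene

The source may report more compounds than this note shows. Statements on the series, on what has been measured and on what is new or still open speak of the compounds shown alone.

Measured compounds:
compound 1, `Cc1[nH]ncc1CN1C[C@H](CCCB(O)O)[C@](N)(C(=O)O)C1` — 400 nM
compound 2, `N[C@@]1(C(=O)O)CN(Cc2ccncc2)C[C@@H]1CCCB(O)O` — 600 nM

In an assay for inhibition of arginase-1 (Homo sapiens), read by colorimetric assay, with a stated time of 60 min, in the presence of a further agent that is not named here (a lower number here means a stronger inhibitor, a higher number a weaker inhibitor), compound 1 gives 400 nM and compound 2 gives 600 nM. Among the measured compounds shown here, of the two numbers, compound 2 has the higher one, but its only neighbour is compound 1, and the step of a 1.5-fold higher number from compound 1 to compound 2 (0.18 log units; within the scatter) does not separate the two beyond the scatter.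

Compound 3, `N[C@@]1(C(=O)O)CN(Cc2cncs2)C[C@@H]1CCCB(O)O`, awaits measurement in this assay. Its change from compound 2 is 1,3-thiazol-5-yl in place of pyridin-4-yl on a saturated chain carbon bound to an amine nitrogen in a ring. For the measured compounds named here, the one measured step that bears on this change is a 1.5-fold higher number from compound 1 to compound 2 (0.18 log units; within the scatter), a replacement of one heteroaryl by another at the same place on the shared core, which left the number within the scatter. Going by the values given here, with no other steps at this place, a change of similar kind is expected to behave similarly: no step beyond the scatter, in either direction, so the expected step is no change at the digits printed from compound 2 to compound 3 (within the scatter).

The estimate for compound 3 in this assay is therefore 600 nM, with a range from 250 nM to 1500 nM.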

Compound 3, half-maximal inhibitory concentration: 360 nM
The estimate for compound 3 lay 1.7-fold (0.22 log units) above the measured number, within the range that was stated.
By their numbers in this assay, from the lowest: compounds 3, 1 and 2 (each within the scatter of the next).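

In this assay, putting 1,3-thiazol-5-yl in place of pyridin-4-yl gives a 1.7-fold lower number from compound 2 to compound 3 (0.22 log units; within the scatter) on a saturated chain carbon bound to an amine nitrogen in a ring, so this place also tolerates a five-membered aromatic ring containing sulfur without a step beyond the scatter. The comparison with the other five-membered ring gives a 1.1-fold lower number from compound 1 to compound 3 (0.05 log units; within the scatter) and completes the set: 5-methyl-1H-pyrazol-4-yl, pyridin-4-yl and 1,3-thiazol-5-yl all lie within the scatter of one another, despite differing in ring size and in hetero atoms. No measurement available here accounts for these three numbers staying so close.

On these data alone, all three groups are aromatic rings with at least one ring nitrogen, so it remains open whether a plain phenyl, or a saturated group such as cyclohexyl, would also stay within the scatter at this place. Also unresolved is whether the attachment point on the ring matters, as a comparison of 1,3-thiazol-5-yl with 1,3-thiazol-2-yl or of pyridin-4-yl with pyridin-2-yl would show, and whether any group here can move the number beyond the scatter.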